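Replacing 4-methoxyphenyl with naphthalen-1-yl on the shared core

This account rests on a few compounds, and the source may have more. Where it says the series, first, only, none or still open, it means among the compounds named here.

Measured in a functional assay (aorta) with Oryctolagus cuniculus as the target; a lower number here means tighter binding, a higher number weaker binding:
- compound 1 `COc1cc(C#N)ccc1OCCCN1CCC(C(c2ccc(F)cc2)c2ccc(F)cc2)CC1`: 2 nM
- compound 2 `COc1ccc(OCCCN2CCC(C(c3ccc(F)cc3)c3ccc(F)cc3)CC2)cc1`: 2.51 nM

Compound 2 stands at 2.51 nM, within the scatter of compound 1 at 2 nM, so this assay does not separate the two.

The next compound, compound 3 `Fc1ccc(C(c2ccc(F)cc2)C2CCN(CCCOc3cccc4ccccc34)CC2)cc1`, has not yet been measured. It carries naphthalen-1-yl in place of 4-methoxyphenyl on an oxygen on a saturated carbon.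

Within the data shown here, only one measured step bears on this change, and it concerns the group at the same place. Replacing 4-cyano-2-methoxyphenyl with 4-methoxyphenyl gave a 1.3-fold higher number from compound 1 to compound 2 (0.10 log units; within the scatter). Among the measured compounds shown here, that single step offers little evidence, and no measured compound carries naphthalen-1-yl, so the direction remains open and the range must stay wide. No step beyond the scatter is therefore expected. The estimated change is a 1.2-fold higher number from compound 2 to compound 3 (0.08 log units; within the scatter). For compound 3 the expected value is 3 nM, with an estimated range from 1 nM to 10 nM.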

Compound 3, dissociation constant: 5.01 nM
Compound 3: the middle estimate sits 1.7-fold (0.22 log units) below what was measured, within the range that was stated.
By their numbers in this assay, from the lowest: compounds 1, 2 and 3 (each within the scatter of the next, the first and the last beyond it).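

At this place, on an oxygen on a saturated carbon, the earlier compounds had shown only substituted phenyl groups, and compound 3 shows that naphthalen-1-yl, with its 2 six-membered aromatic rings and no hydrogen-bond acceptor, can also be carried in this assay. Replacing 4-methoxyphenyl with naphthalen-1-yl gives a 2.0-fold higher number from compound 2 to compound 3 (0.30 log units; within the scatter), so this change alone is not separated by the assay. Among these compounds, replacing 4-cyano-2-methoxyphenyl with the same group gives a 2.5-fold higher number from compound 1 to compound 3 (0.40 log units; beyond the scatter), which is the first step at this position to pass beyond the scatter, though it remains modest and no information at hand accounts for it.

The compounds shown leave open whether naphthalen-2-yl, or a phenyl ring carrying an amine or a carboxylic acid, would stay as close to these numbers as the three groups here do. They also leave open whether naphthalen-1-yl would behave in the same way on a longer chain between the oxygen and the shared core.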